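A Sulfonyl Swap Measured Against an Assay Limit

The source may report more compounds than this note shows. Statements on the series, on what has been measured and on what is new or still open speak of the compounds shown alone.

Compound 1 `O=C(Nc1ccc(-c2noc(-c3cccc(NS(=O)(=O)c4ccc(C(F)(F)F)cc4)c3)n2)c(Cl)c1)c1cccnc1`: > 10000 nM, a limit
Compound 2 `CC(=O)Nc1ccc(S(=O)(=O)Nc2cccc(-c3nc(-c4ccc(NC(=O)c5cccnc5)cc4Cl)no3)c2)cc1Cl`: > 10000 nM, a limit

In a functional assay on MDA-MB-231 cells (Homo sapiens) for antiproliferative activity, read by MTT assay, with a stated time of 72 h (on this read-out lower numbers stand for stronger inhibition and higher numbers for weaker inhibition), compound 1 gives > 10000 nM, which is a limit and not a number. Compound 1 therefore stands at the limit of > 10000 nM in this assay, at which 2 of the 2 values shown sit.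

The compound still to be measured is compound 3 `CC(=O)Nc1ccc(S(=O)(=O)Nc2cccc(-c3nc(-c4ccc(NC(=O)c5cccnc5)cc4Cl)no3)c2)cc1C`. It has 4-acetamido-3-methylphenyl in place of 4-(trifluoromethyl)phenyl on a sulfonyl sulfur.

Going by the values given here, one measured step bears on this change, with 4-acetamido-3-chlorophenyl entering at the same place: a step that the two limits leave unreadable from compound 1 to compound 2. That step supplies no size to carry over, so no step beyond the scatter is expected in this assay, in either direction. The estimated step is a number no higher from compound 1 to compound 3 (the limit leaves the size open). For compound 3 the expected value is 10000 nM, within an estimated range from 4000 nM to 25000 nM.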

Compound 3, half-maximal inhibitory concentration: > 10000 nM
Compound 3 ended at the assay's limit; the forecaster's own chance of this, stated with the estimate: 75%; the middle value sits exactly at the limit.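

No new step can be read from compound 3 against compound 1 or compound 2, because all three give a limit and not a number: the limit of > 10000 nM in this assay, at which 3 of the 3 values shown sit.

As far as these compounds go, how far each compound lies past that limit, and whether the sulfonyl substituents differ at all in this assay, stays open.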